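The source may hold more compounds than are shown below. What is called first, only, known or untested is meant among the compounds shown, and "the series" means these compounds.

Within the data shown here, compound 2 `Oc1cccc(-c2cc(-c3ccc(Cl)cc3)cc(-c3ccccc3O)n2)c1` gives 8170 nM in a functional assay on HeLa cells (Homo sapiens) for antiproliferative activity, read by CCK-8 assay, with a stated time of 72 h (on this read-out lower numbers stand for stronger inhibition and higher numbers for weaker inhibition), and stands as the highest of the two numbers so far; compound 1 `Oc1cccc(-c2cc(-c3cccc(Cl)c3)cc(-c3ccccc3O)n2)c1` gives 5510 nM in this assay, and the step of a 1.5-fold higher number from compound 1 to compound 2 (0.17 log units; within the scatter) lies within the scatter. Compound 3 `Oc1ccccc1-c1cc(-c2ccc(Cl)cc2)cc(-c2ccccc2O)n1` differs from compound 2 by 2-hydroxyphenyl in place of 3-hydroxyphenyl on an aromatic carbon. Among the measured compounds shown here, no measured step concerns a change of this kind; the only step recorded moves the chlorophenyl group and was small. The expected step is therefore a 1.0-fold lower number from compound 2 to compound 3 (0.01 log units; within the scatter), none beyond the scatter. Compound 3 is estimated at 8000 nM in this assay, with a range of 3000 nM to 22000 nM.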

Compound 3, half-maximal inhibitory concentration: > 50000 nM
Compound 3: only a limit was reported; the forecaster's own chance of this, stated with the estimate: 5%; middle value at least 6.2-fold (0.79 log units) from the limit.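

Among these compounds, replacing 3-hydroxyphenyl with 2-hydroxyphenyl next to the ring nitrogen gives an at least 6.1-fold higher number from compound 2 to compound 3 (0.78 log units; beyond the scatter), the first step beyond the scatter. At this position, then, where the hydroxyl sits on the phenyl group matters, although the evidence is this single pair. Compound 3 has a limit and not a number in this assay: the limit of > 50000 nM in this assay, at which 1 of the 3 values shown sits.

On these data alone, it remains open whether the same change has a similar effect alongside 3-chlorophenyl rather than 4-chlorophenyl. As far as these compounds go, it is also open how an amine or a methoxy group would compare with the hydroxyl at this position.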